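A few compounds are considered here, and "the series" means these few. Any claim that something is new, unique, unknown or untested is made for them only; others in the source may bear on it.

Measured compounds in a functional assay on B16 cells (Mus musculus) for cytotoxicity, read by MTT assay; a lower number here means a stronger inhibitor, a higher number a weaker inhibitor:
compound 1 `CC(=O)O[C@@H]1OC(=O)[C@](Cc2ccccc2)(C(C)=O)[C@@H]1C` gives 41000 nM.
compound 2 `CC(=O)O[C@@H]1OC(=O)[C@](O)(C(C)=O)[C@@H]1C` gives only a limit of the assay, > 50000 nM.
compound 3 `CC(=O)O[C@@H]1OC(=O)[C@](OC(C)=O)(C(C)=O)[C@@H]1C` gives only a limit of the assay, > 50000 nM.

Compound 3 therefore stands at a limit, not at a number, and it shares that limit with compound 2: the limit of > 50000 nM in this assay, at which 2 of the 3 values shown sit. The two steps that lead from compound 1 to the limit compounds are an at least 1.2-fold higher number from compound 1 to compound 3 (0.08 log units; that floor lies within the scatter) and an at least 1.2-fold higher number from compound 1 to compound 2 (0.08 log units; that floor lies within the scatter); the step between the two limits, a step that the two limits leave unreadable from compound 2 to compound 3, cannot be read at all.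

Compound 4 `CC(=O)O[C@@H]1OC(=O)[C@@](OC(C)=O)(C(C)=O)[C@@H]1C` is the next compound. It differs from compound 3 as follows: the two compounds have the same atoms and bonds and differ only in configuration as drawn: 1 of 3 stereo elements differ; a stereocentre at a saturated ring carbon is drawn R in compound 3 and S in compound 4. No measured step in this series changes only a configuration; the three steps shown exchange a group on the saturated ring carbon or acetylate an oxygen, and two of them end at the limit. There is thus no measured basis for expecting compound 4 to move away from that limit in either direction, and a step that the limit leaves unreadable from compound 3 to compound 4 is expected, which is within the scatter. The estimate for compound 4 in this assay is 60000 nM, with a range from 30000 nM to 150000 nM, and the most likely outcome is that the assay again reports only a limit rather than a number.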

Compound 4, half-maximal inhibitory concentration: > 50000 nM
Compound 4 gave a limit, no number; the forecaster's own chance of this, stated with the estimate: 70%; the middle value is on the limit's open side.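

In this assay compound 4 gives > 50000 nM, a limit of the assay and not a number. No step can be read between compound 3 and compound 4, as both sit at the same limit: the limit of > 50000 nM in this assay, at which 3 of the 4 values shown sit. From the compounds shown here alone, whether the configuration at the saturated ring carbon changes the read-out at all remains open.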